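Compound 2 to compound 4: one ring exchanged

The source may hold more compounds than are shown below. What is called first, only, known or untested is meant among the compounds shown, and "the series" means these compounds.

compound 1 `O=C(NCC1(c2nc(-c3ccccc3)cs2)CCOCC1)c1ccc(-n2cncn2)cc1` gives 191000 nM
compound 2 `Cc1cnc(Nc2ccc(C(=O)NCC3(c4nc(-c5ccccc5)cs4)CCOCC3)cc2)s1` gives < 1000 nM as a limit
compound 3 `COc1ccccc1-c1csc(C2(CNC(=O)c3ccc(Cn4nc(C)cc4C)cc3)CCOCC2)n1` gives 78000 nM

Compound 2 gives only a limit in a physicochemical assay for solubility, read by chemiluminescence, in phosphate buffer, measured as kinetic solubility, at pH 7.4 (on this read-out higher numbers stand for higher solubility and lower numbers for lower solubility), and no number (the limit of < 1000 nM in this assay, at which 1 of the 3 values shown sits). Compound 4 `Cn1ccc(Nc2ccc(C(=O)NCC3(c4nc(-c5ccccc5)cs4)CCOCC3)cc2)n1` has 1-methyl-1H-pyrazol-3-yl in place of 5-methyl-1,3-thiazol-2-yl on a nitrogen on an aromatic ring. Among the measured compounds shown here, the one measured step that bears on this is the large one an at least 190-fold lower number from compound 1 to compound 2 (2.28 log units; beyond the scatter) and it brought in the (5-methyl-1,3-thiazol-2-yl)amino group. For the measured compounds named here, compound 4 keeps the amino link of that group, and no measured step exchanges the ring itself. The estimated step is an at least 3.0-fold higher number from compound 2 to compound 4 (0.47 log units; beyond the scatter) and it is expected to be a modest rise. The expected value in this assay for compound 4 is 3000 nM (range 1000 nM to 20000 nM).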

Compound 4, solubility: 48000 nM
Beside the measured number, compound 4's estimate is 16-fold (1.20 log units) below it, and the stated range ends below it.
By their numbers in this assay, from the lowest: compounds 4 and 3 (each within the scatter of the next); then compound 1. At a limit, below all of these: compound 2.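

In this assay, exchanging only the ring on the nitrogen changes the result greatly, although 5-methyl-1,3-thiazol-2-yl and 1-methyl-1H-pyrazol-3-yl have the same heavy-atom count: an at least 48-fold higher number from compound 2 to compound 4 (1.68 log units; beyond the scatter). So the amino link does not by itself bring the full fall seen in an at least 190-fold lower number from compound 1 to compound 2 (2.28 log units; beyond the scatter), as the step with 1-methyl-1H-pyrazol-3-yl is smaller, at a 4.0-fold lower number from compound 1 to compound 4 (0.60 log units; beyond the scatter). The size of the first step remains open-ended, as compound 2 gives only a limit: the limit of < 1000 nM in this assay, at which 1 of the 4 values shown sits.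

Still open, going by these compounds, is whether the methyl on the 1-methyl-1H-pyrazol-3-yl ring matters. Also open, on these data alone, is how a carboxylic acid or a simple amine in this place would read in this assay.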